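The source may report more compounds than this note shows. Statements on the series, on what has been measured and on what is new or still open speak of the compounds shown alone.

Going by the values given here, compound 1 `FC(F)(F)c1ccc(NCc2cn(-c3ccccc3)nc2-c2ccc(Br)cc2)cc1` is the only member of this small set with a numeric result in an ADME assay on BHK-21 cells (Mesocricetus auratus) for cytotoxicity, read by MTT assay, with a stated time of 72 h (on this read-out higher numbers stand for lower toxicity in this test and lower numbers for higher toxicity in this test), where compound 1 gives 20000 nM. Compound 2 `Clc1ccc(NCc2cn(-c3ccccc3)nc2-c2ccc(Br)cc2)cc1` reaches only the limit of this assay, with compound 2 reported as > 100000 nM; > 100000 nM (2 entries). Compound 3 `Brc1ccc(-c2nn(-c3ccccc3)cc2CNc2ccccc2)cc1` likewise reaches only a limit, and compound 3 stands at > 100000 nM. Among the compounds with values here, the one step that can be put into numbers, an at least 5.0-fold higher number from compound 1 to compound 3 (0.69 log units; beyond the scatter), is at best a lower bound, since the limit of > 100000 nM in this assay, at which 1 of the 3 values shown sits, caps what can be seen on that side. Compound 4 `FC(F)(F)c1ccc(NCc2cn(-c3ccccc3)nc2-c2ccc(Cl)cc2)cc1` is the untested partner of compound 1, and the change between them is chloro in place of bromo on an aromatic carbon. Within the data shown here, no measured pair touches this part of compound 1; the only step recorded, from compound 1 to compound 3, alters the other aromatic ring and leaves the bromo group untouched, so it offers no direct reading on a chloro in place of bromo on an aromatic carbon. With nothing pointing either way, the expectation is a step that stays within the usual scatter, that is a 1.3-fold higher number from compound 1 to compound 4 (0.10 log units; within the scatter). Compound 4 is therefore estimated at 25000 nM, in the range 8000 nM to 80000 nM in this assay.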

Compound 4, half-maximal cytotoxic concentration: 17000 nM
The estimate for compound 4 lay 1.5-fold (0.17 log units) above the measured number, within the range that was stated.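

Going by these compounds alone, the change of 4-bromophenyl to 4-chlorophenyl is the first one that can be read at this position in this assay, and it gives a 1.2-fold lower number from compound 1 to compound 4 (0.07 log units; within the scatter), so bromo and chloro cannot be told apart here with the trifluoromethyl group in place. Within the data shown here, both ends of this step are numbers, which makes it a full reading, whereas the only earlier step, an at least 5.0-fold higher number from compound 1 to compound 3 (0.69 log units; beyond the scatter), altered the other aromatic ring and left this position untouched. Compound 3 remains a limit and not a number, so that earlier step stays a bound: the limit of > 100000 nM in this assay, at which 1 of the 4 values shown sits.

The compounds shown leave open whether chloro in place of bromo would read the same way without the trifluoromethyl group, as in the shared core of compound 3. Among these compounds, they also leave open what this position would give with hydrogen, fluoro, methoxy, a nitrile or an amine in place of the bromo, as the only change seen here is the one from bromo to chloro.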